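The source may hold more compounds than are shown below. What is called first, only, known or untested is meant among the compounds shown, and "the series" means these compounds.

- Compound 1 `COc1cccc(NC(=O)NCCNS(=O)(=O)c2ccc(-c3ccccc3OCc3ccccc3)s2)c1`: > 20000 nM (a limit)
- Compound 2 `O=C(NCCNS(=O)(=O)c1ccc(-c2ccccc2O[C@H]2CC[C@@H](O)CC2)s1)Nc1cc(C(F)(F)F)cc(C(F)(F)F)c1`: 9300 nM

Among the compounds with values here, in a functional assay on RS4-11 cells (Homo sapiens) for inhibition, read by CCK-8 assay, with a stated time of 48 h (a lower number here means a stronger inhibitor, a higher number a weaker inhibitor), compound 2 gives 9300 nM, the only actual number so far. Compound 1 stands at > 20000 nM, which is a limit of the assay and not a number.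

Compound 3 `O=C(NCCNS(=O)(=O)c1ccc(-c2ccccc2OCc2ccccc2)s1)Nc1cc(C(F)(F)F)cc(C(F)(F)F)c1` has benzyl in place of 4-hydroxycyclohexyl on an oxygen on an aromatic ring. Within the data shown here, no measured step yet shows what this change does, so no shift beyond the usual scatter is expected in this assay, and the estimated step is a 1.0-fold lower number from compound 2 to compound 3 (0.01 log units; within the scatter). Compound 3 is expected at 9000 nM, with an estimated range from 2500 nM to 25000 nM.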

Compound 3, half-maximal inhibitory concentration: > 50000 nM
Compound 3: only a limit was reported; the forecaster's own chance of this, stated with the estimate: 25%; middle value at least 5.5-fold (0.74 log units) away from the limit.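

In this assay, the group on this oxygen proves to matter: benzyl in place of 4-hydroxycyclohexyl gives an at least 5.3-fold higher number from compound 2 to compound 3 (0.73 log units; beyond the scatter) and so a weaker inhibitor, the first measured sign of what this position tolerates. The figure for compound 3 is a limit and not a number: the limit of > 50000 nM in this assay, at which 1 of the 3 values shown sits. The change replaces the non-aromatic ring and removes the hydroxyl together, so the two cannot be told apart. Plain cyclohexyl would separate them, and whether an amine in place of the hydroxyl keeps the activity remains open.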